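The source may hold more compounds than are shown below. What is called first, only, known or untested is meant among the compounds shown, and "the series" means these compounds.

Compound 1, `CCOC(=O)c1oc2ccc(NS(=O)(=O)c3ccc(Br)cc3)cc2c1C`: in a functional assay on HCT-116 cells (Homo sapiens) for inhibition, read by MTT assay, with a stated time of 72 h (a higher number here means a weaker inhibitor, a lower number a stronger inhibitor), compound 1 reaches only the limit, > 40000 nM.
Compound 2, `CCOC(=O)c1oc2ccc(N(Cc3ccccc3)S(=O)(=O)c3ccc(Br)cc3)cc2c1C`: in this assay compound 2 gives 8700 nM.
Compound 3, `CCOC(=O)c1oc2ccc(N(Cc3ccccc3)S(=O)(=O)c3ccc([N+](=O)[O-])cc3)cc2c1C`: in this assay compound 3 reaches only the limit, > 40000 nM.

On these data alone, compound 3 therefore stands at the limit of > 40000 nM in this assay, at which 2 of the 3 values shown sit, so its true value is unknown beyond that bound. Compound 4, `CCOC(=O)c1oc2ccc(N(Cc3ccccc3)S(=O)(=O)c3ccc(F)cc3)cc2c1C`, differs from compound 3 by fluoro in place of nitro on an aromatic carbon. Among the measured compounds shown here, one measured step bears on this: an at least 4.5-fold higher number from compound 2 to compound 3 (0.66 log units; beyond the scatter), which shows that replacing the bromo halogen with nitro weakened compound 3 at least modestly. Returning from nitro to a halogen, fluoro, is expected to undo much of that loss, so the estimated step is an at least 3.3-fold lower number from compound 3 to compound 4 (0.52 log units; beyond the scatter). Compound 4 is accordingly expected at about 12000 nM, within 3000 nM to 40000 nM, near compound 2 rather than at the limit.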

Compound 4, half-maximal inhibitory concentration: 33100 nM
For compound 4 the middle estimate is 2.8-fold (0.44 log units) below the measured one; the measured number falls inside the stated range.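

Not every halogen at this position behaves alike: with 4-fluorophenyl in place of the bromo-bearing ring, the result is a 3.8-fold higher number from compound 2 to compound 4 (0.58 log units; beyond the scatter). The activity of compound 2 therefore belongs to bromo here, not to halogens in general. The other step, an at least 1.2-fold lower number from compound 3 to compound 4 (0.08 log units; that floor lies within the scatter), gives only a floor, so fluoro and nitro cannot be put in order: the limit of > 40000 nM in this assay, at which 2 of the 4 values shown sit.

On these data alone, it remains open whether chloro, which lies among the halogens, would stay close to bromo or fall back towards fluoro. How an amine or a methoxy group would fare at this position is also unknown.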